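From methoxymethyl to methoxy on the aromatic ring

The source may report more compounds than this note shows. Statements on the series, on what has been measured and on what is new or still open speak of the compounds shown alone.

Among the measured compounds shown here, in an in vitro ADME assay on microsomes from liver (Homo sapiens) for metabolic stability (a higher number here means faster removal of the compound, a lower number slower removal), the compounds measured so far stand as follows.
- Compound 1 (`COCc1ccccc1C1Cc2nccn2C1`) gives < 7 mL.min-1.g-1 (a limit, not a number)
- Compound 2 (`COc1ccccc1C1CCc2nc[nH]c2C1`) gives "not determined" (no result reported) (no result)

Compound 1 stands at the limit of < 7 mL.min-1.g-1 in this assay, at which 1 of the 2 values shown sits (a limit of the assay, not a number). For the measured compounds named here, compound 2 has no result, so no measured step exists to lean on.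

Compound 3 (`COc1ccccc1C1Cc2nccn2C1`) has not been measured yet. It keeps the core of compound 1 and alters one group (methoxy in place of methoxymethyl on an aromatic carbon), with methoxy in place of methoxymethyl on an aromatic carbon.

Going by the values given here, the one anchor is compound 1 at < 7 mL.min-1.g-1, which is again a limit. With only that to go on, no direction can be named for the change, and no step beyond the usual scatter is expected in this assay. The estimate amounts to a step that the limit leaves unreadable from compound 1 to compound 3, expected to stay within that scatter. For compound 3 the expected value is 6 mL.min-1.g-1, with an estimated range from 3 mL.min-1.g-1 to 14 mL.min-1.g-1, though the assay may well report only a limit again.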

Compound 3, intrinsic clearance in microsomes: 37 mL.min-1.g-1
The estimate for compound 3 lay 6.2-fold (0.79 log units) below the measured number; measured number above the stated range.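

This result shows that the group on this aromatic carbon matters. With the core of compound 1 left as it is, methoxy in place of methoxymethyl gives an at least 5.2-fold higher number from compound 1 to compound 3 (0.72 log units; beyond the scatter) in this assay, a step beyond the usual scatter of repeated measurements. Before this, no measured step existed and nothing showed whether this read-out would respond to a change at this place, whereas it now clearly does, even though the swap only shortens the group by one carbon and the counts of donors and acceptors stay the same. The true size of the step stays unknown because compound 1 is reported only as a limit, so the real gap could be larger than the printed one: the limit of < 7 mL.min-1.g-1 in this assay, at which 1 of the 3 values shown sits.

On these data alone, this is a single pair, so it remains open whether the faster removal belongs to methoxy in particular or would also appear with other groups on this carbon, such as a hydroxyl, a fluorine atom, an amine or a longer chain like ethoxy. As far as these compounds go, it also remains open whether the same swap would give a similar step on a different core.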